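Expecting compound 3: a smaller group on one nitrogen

The source may hold more compounds than are shown below. What is called first, only, known or untested is meant among the compounds shown, and "the series" means these compounds.

Compound 1 `N#Cc1c(Nc2ccccc2)nc(SCc2nc3ccccc3[nH]2)nc1-c1ccccc1`: 4.46 nM
Compound 2 `N#Cc1c(NNC(N)=S)nc(SCc2nc3ccccc3[nH]2)nc1-c1ccccc1`: 4.54 nM

In a functional assay on HL-60 cells (Homo sapiens) for cytotoxicity, read by MTT assay, with a stated time of 3 days (a higher number here means a weaker inhibitor, a lower number a stronger inhibitor), compound 2 stands level with compound 1, the two values lying within the scatter of each other. Compound 3 `N#Cc1c(NC(N)=S)nc(SCc2nc3ccccc3[nH]2)nc1-c1ccccc1` differs from compound 2 in one place: a group of 3 heavy atoms (1 carbon, 1 nitrogen, 1 sulfur; no ring) in place of a group of 4 heavy atoms (1 carbon, 2 nitrogen, 1 sulfur; no ring), on a nitrogen on an aromatic ring. Among the compounds with values here, the only measured step, a 1.0-fold higher number from compound 1 to compound 2 (0.01 log units; within the scatter), also changed a group on a nitrogen on an aromatic ring, and it stayed within the scatter. The expected change is therefore none beyond the scatter, with an estimated 1.1-fold higher number from compound 2 to compound 3 (0.04 log units; within the scatter). Compound 3 is expected at 5 nM, with an estimated range of 1.5 nM to 17 nM.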

Compound 3, half-maximal inhibitory concentration: 5.81 nM
The estimate for compound 3 lay 1.2-fold (0.07 log units) below the measured number; low and high end bracket the measured number.
By their numbers in this assay, from the lowest: compounds 1, 2 and 3 (each within the scatter of the next).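

In this assay, the shorter group on this nitrogen gives a 1.3-fold higher number from compound 2 to compound 3 (0.11 log units; within the scatter) for the loss of one nitrogen from the chain, and the direct comparison with the group bearing the six-membered aromatic ring gives a 1.3-fold higher number from compound 1 to compound 3 (0.11 log units; within the scatter) across a much larger swap. All three groups on this nitrogen therefore now sit within the scatter of one another, whether or not they carry a ring. Nothing available explains why these numbers stay together. Still open, as far as these compounds go, is whether a simple amine, a carboxylic acid or a longer chain on this nitrogen would also stay level.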